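This account rests on a few compounds, and the source may have more. Where it says the series, first, only, none or still open, it means among the compounds named here.

Measured so far in a functional assay on HL-60 cells (Homo sapiens) for antiproliferative activity, with a stated time of 72 h; a lower number here means a stronger inhibitor, a higher number a weaker inhibitor:
- compound 1 `OC[C@H]1O[C@@H](n2cnc3c(NCc4ccccc4Cl)ncnc32)[C@H](O)[C@@H]1O`: 1600 nM
- compound 2 `OC[C@H]1O[C@@H](n2cnc3c(NCc4ccccc4Br)ncnc32)[C@H](O)[C@@H]1O`: 6600 nM

Compound 2 holds the higher of the two numbers, at 6600 nM, with compound 1 the only other point, at 1600 nM. Next in the series is compound 3 `OC[C@H]1O[C@@H](n2cnc3c(NCc4ccccc4OC(F)(F)F)ncnc32)[C@H](O)[C@@H]1O`, not yet measured. The change from compound 2 is trifluoromethoxy in place of bromo on an aromatic carbon, ortho to a large group.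

Within the data shown here, only one measured step bears on this: a 4.1-fold higher number from compound 1 to compound 2 (0.62 log units; beyond the scatter). That step is modest, comes from a single pair and exchanges one halogen for another. Among the measured compounds shown here, no measured compound carries trifluoromethoxy, so the data give no firm direction for the new group. For the measured compounds named here, a change no larger than that step is the working expectation, with a slight lean toward a lower number and either direction still open.

The expected step in this assay is a 1.3-fold lower number from compound 2 to compound 3 (0.12 log units; within the scatter). For compound 3 the estimated value is 5000 nM, with an expected range of 1500 nM to 16000 nM.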

Compound 3, half-maximal inhibitory concentration: > 166000 nM
Compound 3: a limit, no number; the forecaster's own chance of this, stated with the estimate: 8%; middle value at least 33-fold (1.52 log units) away from the limit.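

In this assay compound 3 carries a limit and not a number: the limit of > 166000 nM in this assay, at which 1 of the 3 values shown sits.

Set against the two halogens, the trifluoromethoxy exchange gives an at least 25-fold higher number from compound 2 to compound 3 (1.40 log units; beyond the scatter) and an at least 100-fold higher number from compound 1 to compound 3 (2.01 log units; beyond the scatter), both large, whereas the exchange of chloro for bromo gave only a 4.1-fold higher number from compound 1 to compound 2 (0.62 log units; beyond the scatter). The position, on an aromatic carbon ortho to a large group, is therefore far from indifferent to what sits there: with chloro and bromo the series keeps a measurable value, while the exchange to trifluoromethoxy, which brings 5 heavy atoms in place of 1 and adds 1 hydrogen-bond acceptor, leaves only a limit.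

Which feature of the trifluoromethoxy group goes with this loss stays open, and the true size of the step stays open with it, since only its lower bound can be read. A methoxy or a trifluoromethyl group on the same carbon would separate the part played by the oxygen from that played by the fluorines.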